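Swapping Bromophenyl for Ethylphenyl on a Sulfonamide

The source may report more compounds than this note shows. Statements on the series, on what has been measured and on what is new or still open speak of the compounds shown alone.

Compound 1 `CCCCCc1ccc(NS(=O)(=O)c2ccc(N3CCNC3=O)cc2)cc1`: 990 nM
Compound 2 `O=C1NCCN1c1ccc(S(=O)(=O)Nc2cccc(Br)c2)cc1`: 77 nM

Among the compounds with values here, in a functional assay on HT-29 cells (Homo sapiens) for antiproliferative activity, read by sulforhodamine B assay, with a stated time of 48 h (on this read-out lower numbers stand for stronger inhibition and higher numbers for weaker inhibition), compound 2 gives 77 nM, the lowest of the two numbers measured so far; compound 1 gives 990 nM, a higher number that lies beyond the scatter. Compound 3 `CCc1ccc(NS(=O)(=O)c2ccc(N3CCNC3=O)cc2)cc1` is not yet measured. It differs from compound 2 by 4-ethylphenyl in place of 3-bromophenyl on a sulfonamide nitrogen. The change moves toward the kind of group seen in compound 1. The expected step of a 5.2-fold higher number from compound 2 to compound 3 (0.72 log units; beyond the scatter) is toward weaker inhibition, beyond the scatter. Compound 3 is estimated at 400 nM, with a range from 120 nM to 1500 nM.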

Compound 3, half-maximal inhibitory concentration: 660 nM
Compound 3: middle estimate off by 1.7-fold (0.22 log units), on the low side; low and high end bracket the measured number.
By their numbers in this assay, from the lowest: compound 2; then compounds 3 and 1 (each within the scatter of the next).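

In this assay, the group on the sulfonamide nitrogen clearly matters: 4-ethylphenyl in place of 3-bromophenyl gives an 8.6-fold higher number from compound 2 to compound 3 (0.93 log units; beyond the scatter). By contrast, hydrogen in place of propyl on the saturated chain gives a 1.5-fold lower number from compound 1 to compound 3 (0.18 log units; within the scatter), so this chain difference does not separate compound 1 and compound 3. Nothing measured here accounts for either result. The first step changes both the substituent and its ring position, and these remain tangled together. A 3-ethylphenyl or 4-bromophenyl group on the same nitrogen would pull them apart.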